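Moving the naphthalene attachment point in a thiazoloimidazole oxime ether series

The source may report more compounds than this note shows. Statements on the series, on what has been measured and on what is new or still open speak of the compounds shown alone.

Three compounds have been measured in an assay on HepG2 cells for agonist activity at nuclear receptor subfamily 1 group I member 3 (Homo sapiens), read by a luciferase reporter, with a stated time of 23 h; on this read-out lower numbers stand for an effect already at smaller amounts and higher numbers for an effect only at larger amounts of compound:

compound 1, `Clc1ccc(CO/N=C/c2c(-c3cccc4ccccc34)nc3sccn23)cc1Cl`: 940 nM
compound 2, `CC(C)(C)c1ccc(-c2nc3sccn3c2/C=N/OCc2ccc(Cl)c(Cl)c2)cc1`: 2400 nM
compound 3, `Fc1ccc(-c2nc3sccn3c2/C=N/OCc2ccc(Cl)c(Cl)c2)cc1`: 670 nM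

Compound 3 gives the lowest of the three numbers. Its nearest neighbour is compound 1, and the step of a 1.4-fold lower number from compound 1 to compound 3 (0.15 log units; within the scatter) lies within the scatter, so the two cannot be ranked against each other. Compound 2 is furthest away, the step of a 3.6-fold lower number from compound 2 to compound 3 (0.55 log units; beyond the scatter) being beyond the scatter, as is the step of a 2.6-fold higher number from compound 1 to compound 2 (0.41 log units; beyond the scatter).

Compound 4, `Clc1ccc(CO/N=C/c2c(-c3ccc4ccccc4c3)nc3sccn23)cc1Cl`, has not yet been measured. It differs from compound 3 in one place: naphthalen-2-yl in place of 4-fluorophenyl on an aromatic carbon. Among the measured compounds shown here, the step that bears most directly on this change is the one from compound 1 to compound 3, which shows that exchanging a naphthalenyl group for 4-fluorophenyl changed the number only within the scatter. For the measured compounds named here, no measured step covers the naphthalen-2-yl attachment itself, so the comparison rests on that single pair. On this basis the step of a 1.5-fold higher number from compound 3 to compound 4 (0.17 log units; within the scatter) is expected to be small, at most a modest rise, given that compound 1 already gave 940 nM. Compound 4 is therefore estimated at 1000 nM, with a range from 350 nM to 3000 nM.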

Compound 4, half-maximal effective concentration: 380 nM
Compound 4: middle estimate off by 2.6-fold (0.42 log units), on the high side, within the range that was stated.
By their numbers in this assay, from the lowest: compounds 4, 3 and 1 (each within the scatter of the next, the first and the last beyond it); then compound 2.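

In this assay, among the compounds shown here, exchanging naphthalen-1-yl for naphthalen-2-yl on this aromatic carbon gives a 2.5-fold lower number from compound 1 to compound 4 (0.39 log units; beyond the scatter), which shows for the first time that the attachment point of the naphthalene, and not only the choice of group, can move the number beyond the scatter. Replacing 4-fluorophenyl with naphthalen-2-yl adds a second six-membered aromatic ring and gives a 1.8-fold lower number from compound 3 to compound 4 (0.25 log units; within the scatter), so the two compounds cannot be ranked against each other, and this larger group carries no measurable penalty relative to 4-fluorophenyl. Replacing 4-(tert-butyl)phenyl with naphthalen-2-yl gives a 6.3-fold lower number from compound 2 to compound 4 (0.80 log units; beyond the scatter), the widest step among these four compounds, so at this position the number depends on which aryl group is present and how it is attached, not simply on the presence of a large group.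

Nothing available explains why the attachment point matters. On these data alone, it also remains open how a quinolinyl or pyridinyl ring would behave on this carbon, or how a methoxy group or a carboxylic acid carried on the naphthalen-2-yl group would shift the number.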